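Cytotoxicity notes: aryl swap on the shared core

The source may report more compounds than this note shows. Statements on the series, on what has been measured and on what is new or still open speak of the compounds shown alone.

Two compounds of the series carry a measured value. Compound 1, `CN(C)CCCC(=O)Nc1ccc(CN2N=C(c3ccc(F)cc3)C3C=CC=CC3C2=O)cc1`, gives 38200 nM in an ADME assay on Huh-7 cells (Homo sapiens) for cytotoxicity, read by MTT assay, with a stated time of 48 h; on this read-out lower numbers stand for higher toxicity in this test and higher numbers for lower toxicity in this test. Compound 2, `CN(C)CCCCOC(=O)Nc1ccc(Cn2nc(-c3cccnc3)c3ccccc3c2=O)cc1`, gives 68000 nM in this assay, the highest of the two numbers in hand; its nearest neighbour is compound 1, and the gap between the two lies within the usual scatter, so the two cannot be told apart on this read-out.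

Compound 3, `CN(C)CCCCOC(=O)Nc1ccc(Cn2nc(-c3ccc(C(F)(F)F)cc3)c3ccccc3c2=O)cc1`, is not yet measured. It differs from compound 2 in one place: 4-(trifluoromethyl)phenyl in place of pyridin-3-yl on an aromatic carbon. For the measured compounds named here, the two measured compounds do not form a matched pair in any single position, so no measured step is available to anchor this change. Going by the values given here, with only two numbers, both within scatter of each other, the working assumption is that the step in this assay will stay within the scatter, with no direction favoured.

Compound 3 is accordingly expected to give about 50000 nM in this assay, within 15000 nM to 150000 nM. The estimated step is a 1.4-fold lower number from compound 2 to compound 3 (0.13 log units; within the scatter).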

Compound 3, half-maximal cytotoxic concentration: 3360 nM
Compound 3: the middle estimate sits 15-fold (1.17 log units) above what was measured, outside the stated range (below it).
By their numbers in this assay, from the lowest: compound 3; then compounds 1 and 2 (each within the scatter of the next).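

For the compounds shown here, this position on the shared core, an aromatic carbon next to the ring nitrogen, is not a silent one in this assay: 4-(trifluoromethyl)phenyl in place of pyridin-3-yl gives a 20-fold lower number from compound 2 to compound 3 (1.31 log units; beyond the scatter), the first matched step and one that points to higher toxicity in this test. The swap alters two things at once, since the ring nitrogen leaves and a trifluoromethyl group enters, with the group growing from 6 to 10 heavy atoms, so the step belongs to the change as a whole and not to either part. Nothing measured here bears on why the number falls so far.

Which part of the change carries the step stays open: plain phenyl at this position would separate the loss of the ring nitrogen from the arrival of the trifluoromethyl group, and 4-chlorophenyl or 4-methoxyphenyl would show whether other substituents on the phenyl ring do the same. Going by these compounds alone, also open is whether the step holds with a side chain other than the one shared by compound 2 and compound 3, such as a shorter amine chain.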